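The compounds below may be only part of what the source reports. "The series", "measured", "known", "first", "only" and "open" are said of these compounds alone.

Measured compounds:
- compound 1, `CC(C(=O)NCc1ccc(C(F)(F)F)cc1OCc1ccc(F)cc1)c1ccc(NS(C)(=O)=O)c(F)c1`: 0.5 nM
- compound 2, `CCCCSc1cc(C(F)(F)F)ccc1CNC(=O)C(C)c1ccc(NS(C)(=O)=O)c(F)c1`: 1.9 nM

In an assay on CHO cells for antagonist activity at transient receptor potential cation channel subfamily V member 1 (Homo sapiens), read by FLIPR (on this read-out higher numbers stand for weaker inhibition and lower numbers for stronger inhibition), compound 1 gives 0.5 nM and compound 2 gives 1.9 nM. Among the compounds with values here, compound 2 thus stands at the higher of the two numbers in this assay; its nearest neighbour is compound 1, and the one step seen so far, a 3.8-fold higher number from compound 1 to compound 2 (0.58 log units; beyond the scatter), runs from the (4-fluorobenzyl)oxy group to the butylsulfanyl group.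

Compound 3, `CC(C(=O)NCc1ccc(C(F)(F)F)cc1-c1cccc(F)c1)c1ccc(NS(C)(=O)=O)c(F)c1`, is not yet measured. It differs from compound 2 in one place: 3-fluorophenyl in place of butylsulfanyl on an aromatic carbon. Within the data shown here, the only step that bears on this change is a 3.8-fold higher number from compound 1 to compound 2 (0.58 log units; beyond the scatter), where a substituent carrying a fluorinated six-membered aromatic ring gave the lower number and the butylsulfanyl chain the higher one. Compound 3 again carries a fluorinated six-membered aromatic ring at that carbon, so a modest move back toward the lower number is expected, of about the size seen before; the step of a 2.4-fold lower number from compound 2 to compound 3 (0.38 log units; beyond the scatter) is the estimated change. On that basis compound 3 is expected to give about 0.8 nM in this assay, with a range of 0.3 nM to 2.5 nM.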

Compound 3, inhibition constant: 1.9 nM
Compound 3: middle estimate off by 2.4-fold (0.38 log units), on the low side; low and high end bracket the measured number.
By their numbers in this assay, from the lowest: compound 1; then compounds 2 and 3 (each within the scatter of the next).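

In this assay, placing 3-fluorophenyl on this aromatic carbon, ortho to a large group and meta to a trifluoromethyl group, yields no change at the digits printed from compound 2 to compound 3 (within the scatter) even though the two groups are quite unlike: butylsulfanyl has no ring, while 3-fluorophenyl carries one six-membered aromatic ring of carbon only. The step of a 3.8-fold higher number from compound 1 to compound 3 (0.58 log units; beyond the scatter) shows that a fluorinated six-membered aromatic ring at this carbon is not enough on its own to reach the number of compound 1, which remains separated beyond the scatter from both compound 2 and compound 3. No measurement at hand accounts for these numbers.

From the compounds shown here alone, it remains open which feature of the (4-fluorobenzyl)oxy group goes with the lower number, since its oxygen link, the benzyl arrangement and the placing of the fluorine all differ from 3-fluorophenyl at once. An unsubstituted benzyloxy group, a butoxy chain or a 4-fluorophenyl group at this carbon would begin to separate these features.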